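Swapping the aryl on the ring nitrogen of compound 2

The source may report more compounds than this note shows. Statements on the series, on what has been measured and on what is new or still open speak of the compounds shown alone.

Compound 2 `COc1ccc(N2CCN(CCCSc3nc4cc(Cl)ccc4[nH]3)CC2)cc1` carries a 4-methoxyphenyl on an amine nitrogen in a ring of the shared core. Among the compounds with values here, in a functional assay on MCF7 cells (Homo sapiens) for cytotoxicity, read by MTT assay, with a stated time of 24 h (on this read-out lower numbers stand for stronger inhibition and higher numbers for weaker inhibition), compound 2 gives 38500 nM, the higher of the two numbers measured so far. Within the data shown here, its only neighbour is compound 1 `CN1CCN(CCCSc2nc3cc(Cl)ccc3[nH]2)CC1`, which bears a methyl at the same place; in this assay compound 1 gives 13900 nM. Among the measured compounds shown here, the single measured step is a 2.8-fold higher number from compound 1 to compound 2 (0.44 log units; beyond the scatter), a modest rise that lies beyond the scatter.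

Compound 3 `Clc1cccc(N2CCN(CCCSc3nc4cc(Cl)ccc4[nH]3)CC2)c1` differs from compound 2 by 3-chlorophenyl in place of 4-methoxyphenyl on an amine nitrogen in a ring. For the measured compounds named here, the one measured step exchanged a methyl for an aryl, whereas this change exchanges one aryl for another of similar size, so no measured step speaks directly to it. With nothing to indicate a direction, the expectation is a step that stays within the scatter. The estimated step is a 1.1-fold lower number from compound 2 to compound 3 (0.04 log units; within the scatter). Compound 3 is therefore expected to give about 35000 nM in this assay, with a range from 15000 nM to 90000 nM reflecting the absence of a guiding precedent.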

Compound 3, half-maximal inhibitory concentration: 61400 nM
Compound 3: the middle estimate sits 1.8-fold (0.24 log units) below what was measured; measured number inside the range.
By their numbers in this assay, from the lowest: compound 1; then compounds 2 and 3 (each within the scatter of the next).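

In this assay the exchange of one aryl for the other gives a 1.6-fold higher number from compound 2 to compound 3 (0.20 log units; within the scatter) and so the 4-methoxyphenyl and the 3-chlorophenyl on the ring nitrogen cannot be told apart, even though one carries an oxygen and the other a chlorine. The second step from methyl to an aryl at this position is a 4.4-fold higher number from compound 1 to compound 3 (0.65 log units; beyond the scatter) and it points the same way as a 2.8-fold higher number from compound 1 to compound 2 (0.44 log units; beyond the scatter) so that, among these three compounds, none goes against the reading that both aryl groups give a higher number than methyl, and compound 1 stands as the most potent of the three. Nothing shown accounts for these numbers.

On these data alone, whether this holds for other groups at the same ring nitrogen remains open, for example a hydrogen, an ethyl or a benzyl, and it is also unclear whether a 4-chlorophenyl would differ from the 3-chlorophenyl. The three compounds also say nothing about whether a shorter or longer chain in the shared core would change the picture.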